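A few compounds are considered here, and "the series" means these few. Any claim that something is new, unique, unknown or untested is made for them only; others in the source may bear on it.

Measured compounds:
Compound 1, `CN(C)CCNC(=O)c1c(O)c2cccnc2n(-c2ccccc2)c1=O`: 18.4%
Compound 2, `O=C(Nc1ccc([N+](=O)[O-])cc1)c1c(O)c2cccnc2n(-c2ccccc2)c1=O`: -25.8%
Compound 3, `O=C(Nc1ccncc1)c1c(O)c2cccnc2n(-c2ccccc2)c1=O`: 24.3%

In a functional assay on the whole organism for inhibition, with Rattus norvegicus as the target, read by cytopathic effect and paw edema, at a dose of 100 mg/kg by the oral route (on this read-out lower numbers stand for less inhibition and higher numbers for more inhibition at the one dose given (going by the name of the read-out)), compound 1 gives 18.4%, the second highest of the three numbers. Its nearest neighbour is compound 3, whose result, 24.3%, lies within the scatter of it, as the step of a number 5.9 percentage points higher from compound 1 to compound 3 (within the scatter) shows. The far end is compound 2, which gives -25.8%; the step of a number 44.2 percentage points lower from compound 1 to compound 2 (beyond the scatter) is large, as is the step back up, a number 50.1 percentage points higher from compound 2 to compound 3 (beyond the scatter).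

The unmeasured compound 4, `Cc1cnccc1NC(=O)c1c(O)c2cccnc2n(-c2ccccc2)c1=O`, differs from compound 1 in one place: 3-methylpyridin-4-yl in place of 2-(dimethylamino)ethyl on an amide-type nitrogen. For the measured compounds named here, the step that bears on this most closely is a number 5.9 percentage points higher from compound 1 to compound 3 (within the scatter), since compound 3 carries the group that differs from the one entering compound 4 only by a methyl group. That step stayed within the scatter, so the expected step of a number 3.6 percentage points higher from compound 1 to compound 4 (within the scatter) is likewise small, with no clear direction beyond the scatter. Compound 4 is therefore estimated at 22%, with a range from 2% to 42%.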

Compound 4, a percentage reported as inhibition, in the whole organism at one dose (the size of the read-out at that dose, not a potency): 8.8%
Estimate against measurement, compound 4: 13.2 percentage points above, within the range that was stated.
By their numbers in this assay, from the lowest: compound 2; then compounds 4, 1 and 3 (each within the scatter of the next, the first and the last beyond it).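

In this assay, for the compounds shown here, the step of a number 15.5 percentage points lower from compound 3 to compound 4 (beyond the scatter) shows for the first time that a change as small as methyl in place of hydrogen on an aromatic carbon can move the result beyond the scatter. The step of a number 9.6 percentage points lower from compound 1 to compound 4 (within the scatter), by contrast, stays within the scatter, so the 3-methylpyridin-4-yl and 2-(dimethylamino)ethyl groups cannot be told apart on this amide-type nitrogen. The step of a number 34.6 percentage points higher from compound 2 to compound 4 (beyond the scatter) leaves compound 2, with its 4-nitrophenyl group, alone at the low end of the series.

Nothing shown here explains any of these steps. From the compounds shown here alone, it remains open how a plain phenyl ring, or a longer chain ending in an amine, would read on the same amide-type nitrogen.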